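The source may report more compounds than this note shows. Statements on the series, on what has been measured and on what is new or still open speak of the compounds shown alone.

Measured compounds in an assay on isolated protein for binding affinity to B1 bradykinin receptor (Homo sapiens); on this read-out higher numbers stand for weaker inhibition and lower numbers for stronger inhibition:

compound 1 `Cc1cc(C)c2cccc(OCc3c(Cl)ccc(S(=O)(=O)NC4(C(=O)N5CCN(C(=O)[C@@H](N)CCCCN)CC5)CCCC4)c3Cl)c2n1` — in this assay compound 1 gives only a limit, < 10000 nM.
compound 2 `Cc1cc(C)c2cccc(OCc3c(Cl)ccc(S(=O)(=O)NC4(C(=O)N5CCN(C(=O)[C@H](CCCCN)[N+](C)(C)C)CC5)CCCC4)c3Cl)c2n1` — in this assay compound 2 gives only a limit, < 10000 nM.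
compound 3 `Cc1cc(C)c2cccc(OCc3c(Cl)ccc(S(=O)(=O)NC4(C(=O)N5CCN(C(=O)[C@@H](N)CCC[N+](C)(C)C)CC5)CCCC4)c3Cl)c2n1` — in this assay compound 3 gives only a limit, < 10000 nM.

All three share one core and differ only in the chain attached to the carbonyl carbon on the piperazine side. From compound 1 to compound 2 the change is a group of 4 heavy atoms (3 carbon, 1 nitrogen; no ring) in place of one nitrogen atom, on a saturated chain carbon bound to a carbonyl carbon and a saturated chain carbon. Its size is a step that the two limits leave unreadable from compound 1 to compound 2, since (the limit of < 10000 nM in this assay, at which 3 of the 3 values shown sit).

The cores of compound 1 and compound 3 differ by a group of 4 heavy atoms (3 carbon, 1 nitrogen; no ring) in place of a group of 2 heavy atoms (1 carbon, 1 nitrogen; no ring), on a saturated chain carbon, four bonds along the chain from an amine nitrogen and a carbonyl carbon; that step, too, is a step that the two limits leave unreadable from compound 1 to compound 3. Compound 2 and compound 3 differ by a step that the two limits leave unreadable from compound 2 to compound 3.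

Compound 4 `Cc1cc(C)c2cccc(OCc3c(Cl)ccc(S(=O)(=O)NC4(C(=O)N5CCN(C(=O)[C@H](CCC[N+](C)(C)C)[N+](C)(C)C)CC5)CCCC4)c3Cl)c2n1` is not yet measured. It differs from compound 3 by a group of 4 heavy atoms (3 carbon, 1 nitrogen; no ring) in place of one nitrogen atom, on a saturated chain carbon bound to a carbonyl carbon and a saturated chain carbon, the same change as from compound 1 to compound 2, at a place described in the same words.

Because (the limit of < 10000 nM in this assay, at which 3 of the 3 values shown sit), nothing measured sets the size of that change, and the expectation for compound 4 can only be that it stays near the limit. The expected step from compound 3 to compound 4 is a number no lower from compound 3 to compound 4 (the limit leaves the size open). For compound 4 the estimated value in this assay is 10000 nM, expected to be reported again as a limit more likely than as a number.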

Compound 4, inhibition constant: < 10000 nM
Compound 4 was reported as a limit (the forecaster's own chance of this, stated with the estimate: 85%); the middle value sits exactly at the limit.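

No step among compound 1, compound 2, compound 3 and compound 4 can be read in this assay, because every value is a limit: the limit of < 10000 nM in this assay, at which 4 of the 4 values shown sit.

The compounds shown leave open how strong the inhibition by each one is in this assay, and whether replacing amino with the group of 4 heavy atoms changes it at all.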